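Indan-2-yl Ester Replacing the Alkenyl Ester on a Dihydropyridine

The source may hold more compounds than are shown below. What is called first, only, known or untested is meant among the compounds shown, and "the series" means these compounds.

Measured compounds:
compound 1 `CCOC(=O)C1=C(C)NC(/C=C/C#N)=C(C(=O)OCC)C1c1cccc([N+](=O)[O-])c1`, 45 nM
compound 2 `C=C(C)CCOC(=O)C1=C(C)NC(C)=C(C(=O)OC)C1c1cccc([N+](=O)[O-])c1`, 47 nM

In a functional assay on HEK293 cells for antagonist activity at Voltage-dependent L-type calcium channel subunit alpha-1D (Rattus norvegicus), read by FLIPR (a higher number here means a weaker inhibitor, a lower number a stronger inhibitor), compound 1 gives 45 nM and compound 2 gives 47 nM. Compound 2 has the higher of the two numbers, but its gap to compound 1 lies within the scatter, so the two stand level. Compound 3 `COC(=O)C1=C(C)NC(C)=C(C(=O)OC2Cc3ccccc3C2)C1c1cccc([N+](=O)[O-])c1` differs from compound 2 by 2,3-dihydro-1H-inden-2-yl in place of 3-methylbut-3-en-1-yl on an oxygen next to a carbonyl group. Among the compounds with values here, no measured pair shows this change, so in this assay the step from compound 2 to compound 3 is expected to stay near the scatter, estimated as a 1.3-fold lower number from compound 2 to compound 3 (0.13 log units; within the scatter). Compound 3 is therefore expected to give about 35 nM, within a range of 10 nM to 150 nM.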

Compound 3, half-maximal inhibitory concentration: 43 nM
Compound 3: middle estimate off by 1.2-fold (0.09 log units), on the low side, within the range that was stated.
By their numbers in this assay, from the lowest: compounds 3, 1 and 2 (each within the scatter of the next).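

At this place, on an oxygen next to a carbonyl group, a group with 9 heavy atoms and two rings replaces an open chain of 5 heavy atoms, giving a 1.1-fold lower number from compound 2 to compound 3 (0.04 log units; within the scatter) in this assay. The position therefore accepts 2,3-dihydro-1H-inden-2-yl as well as 3-methylbut-3-en-1-yl, and compound 2 and compound 3 stand level. Nothing available explains this result.

As far as these compounds go, it remains open whether a chain ending in an amine or a carboxylic acid would also stand level here. Cyclopentyl on the same oxygen would show whether the aromatic ring of 2,3-dihydro-1H-inden-2-yl is needed.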